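A few compounds are considered here, and "the series" means these few. Any claim that something is new, unique, unknown or untested is made for them only; others in the source may bear on it.

Two compounds of this series have numbers in a functional assay on CHO-K1 cells for antagonist activity at C-X-C chemokine receptor type 3 (Homo sapiens), read by FLIPR and calcium flux (on this read-out lower numbers stand for stronger inhibition and higher numbers for weaker inhibition), so far. Compound 1 `CC1CN(c2ccc(C(F)(F)F)cn2)CCN1S(=O)(=O)C[C@]12CC[C@H](CC1=O)C2(C)C` gives 631 nM there. Compound 2 `CC1(C)[C@@H]2CC[C@@]1(CS(=O)(=O)N1CCN(c3ccc(Br)cn3)CC1)C(=O)C2` gives 1580 nM, the highest of the two, and its gap to compound 1 lies beyond the usual scatter. Compound 3 `CC(=O)c1ccc(N2CCN(S(=O)(=O)C[C@]34CC[C@H](CC3=O)C4(C)C)CC2)nc1` is not yet measured; it differs from compound 2 by acetyl in place of bromo on an aromatic carbon. Among the measured compounds shown here, no measured pair shows this exchange, so its effect is unknown. The step from compound 2 to compound 3 is expected to stay within the scatter, a 1.4-fold lower number from compound 2 to compound 3 (0.16 log units; within the scatter). For compound 3 the estimate in this assay is 1100 nM, with a range from 350 nM to 3500 nM.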

Compound 3, half-maximal inhibitory concentration: > 31600 nM
Compound 3 gave a limit, no number; the forecaster's own chance of this, stated with the estimate: 10%; middle value at least 28-fold (1.45 log units) away from the limit.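

In this assay, among the compounds shown here, acetyl in place of bromo on the aromatic carbon para to a large group gives an at least 20-fold higher number from compound 2 to compound 3 (1.30 log units; beyond the scatter), the first single-place step at this position. This position of the six-membered aromatic ring is therefore not indifferent to the group it carries, at least for this one exchange. The result for compound 3 is a limit, not a number: the limit of > 31600 nM in this assay, at which 1 of the 3 values shown sits.

This single pair cannot say how far inhibition falls beyond the limit. Going by these compounds, how a nitrile or a methoxy group would read at this position remains open.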